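This account rests on a few compounds, and the source may have more. Where it says the series, first, only, none or still open, it means among the compounds named here.

In a functional assay on PC-3 cells (Homo sapiens) for inhibition, read by sulforhodamine B assay, with a stated time of 72 h (on this read-out higher numbers stand for weaker inhibition and lower numbers for stronger inhibition), compound 3 `Nc1sc(-c2ccc(Cl)cc2)c(-c2ccc(Cl)cc2)c1C(=O)N1CCCC1` gives 6220 nM and compound 2 `Nc1sc(-c2ccc(Cl)cc2)c(-c2ccc(Cl)cc2)c1C(=O)N1CCOCC1` gives 11700 nM. These two values cannot be told apart, as a 1.9-fold lower number from compound 2 to compound 3 (0.27 log units; within the scatter) shows. Compound 1 `Nc1sc(-c2ccc(Cl)cc2)c(-c2ccc(Cl)cc2)c1C(=O)Nc1ccccc1` gives > 50000 nM, which is a limit of the assay and not a number. Compound 3 therefore shares the low end of this small set with compound 2.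

Compound 4 `Nc1sc(-c2ccc(Cl)cc2)c(-c2ccc(Cl)cc2)c1C(=O)NCc1ccccc1` changes one group of compound 3: it has benzylamino in place of pyrrolidin-1-yl on a carbonyl carbon, (benzylamino in place of pyrrolidin-1-yl on a carbonyl carbon). The closest measured guide is an at least 8.0-fold lower number from compound 1 to compound 3 (0.90 log units; beyond the scatter), a change beyond the scatter that replaces anilino with pyrrolidin-1-yl. The change an at least 4.2-fold lower number from compound 1 to compound 2 (0.63 log units; beyond the scatter), with morpholin-4-yl replacing anilino, points the same way. Benzylamino resembles the anilino of compound 1 more than either ring amine, since both carry an aromatic ring, so the number should move back toward that limit. A higher number is therefore expected, with an estimated 3.2-fold higher number from compound 3 to compound 4 (0.51 log units; beyond the scatter). For compound 4 the estimated value is 20000 nM, with an expected range of 8000 nM to 50000 nM.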

Compound 4, half-maximal inhibitory concentration: 31800 nM
For compound 4 the middle estimate is 1.6-fold (0.20 log units) below the measured one, within the range that was stated.
By their numbers in this assay, from the lowest: compounds 3 and 2 (each within the scatter of the next); then compound 4. At a limit, above all of these: compound 1.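

In this assay, benzylamino on this carbonyl carbon gives weaker inhibition than either ring amine, with a 5.1-fold higher number from compound 3 to compound 4 (0.71 log units; beyond the scatter) and a 2.7-fold higher number from compound 2 to compound 4 (0.43 log units; beyond the scatter). Going by these compounds alone, until now anilino was the only group set against the ring amines; compound 4 shows that a second group with the amide hydrogen and a carbon-only aromatic ring also gives a higher number than both, though these compounds cannot tell which of those two features matters. Benzyl in place of phenyl on an amide-type nitrogen gives an at least 1.5-fold lower number from compound 1 to compound 4 (0.19 log units; that floor lies within the scatter), so this step shows no clear difference. Compound 1 stands at a limit and not at a number: the limit of > 50000 nM in this assay, at which 1 of the 4 values shown sits.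

Going by these compounds, it remains open how a small open-chain group with the amide hydrogen but no aromatic ring, such as ethylamino, would compare with benzylamino. The same holds for a ring amine that carries an aromatic ring, such as 4-phenylpiperidin-1-yl.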